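This account rests on a few compounds, and the source may have more. Where it says the series, first, only, none or still open, it means among the compounds named here.

Working notes on the series. Among the measured compounds shown here, compound 1 `CO[C@@H]1CC=C2NN(c3cc(F)cc(Cl)c3)C(=O)C[C@]2(c2ccccc2)O1` and compound 2 `CO[C@@H]1CC=C2NN(c3cccnc3)C(=O)C[C@]2(C)O1` share one core and differ in more than one place, so no single step connects them. In a functional assay on HCT-116 cells (Homo sapiens) for inhibition, read by sulforhodamine B assay, with a stated time of 48 h (on this read-out lower numbers stand for stronger inhibition and higher numbers for weaker inhibition), compound 1 gives 16200 nM and compound 2 gives 17100 nM; the two numbers lie within the scatter of each other, and neither is ranked against the other. Compound 3 `CO[C@@H]1CC=C2NN(c3cncnc3)C(=O)C[C@]2(C)O1` is derived from compound 2 by pyrimidin-5-yl in place of pyridin-3-yl on an amide-type nitrogen in a ring. For the measured compounds named here, no measured pair shows this change, so its size is unknown. Compound 3 is expected to remain close to compound 2, the step of a 1.2-fold higher number from compound 2 to compound 3 (0.07 log units; within the scatter) being small and not clearly beyond the scatter. The estimate for compound 3 is 20000 nM, with a range of 8000 nM to 50000 nM.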

Compound 3, half-maximal inhibitory concentration: 15100 nM
For compound 3 the middle estimate is 1.3-fold (0.12 log units) above the measured one; low and high end bracket the measured number.
By their numbers in this assay, from the lowest: compounds 3, 1 and 2 (each within the scatter of the next).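

In this assay, among the compounds shown here, pyrimidin-5-yl in place of pyridin-3-yl on the amide-type nitrogen in a ring gives a 1.1-fold lower number from compound 2 to compound 3 (0.05 log units; within the scatter) as the first single-place step. At this position, with a methyl group on the shared core, the two aromatic groups cannot be told apart, despite the second ring nitrogen and second hydrogen-bond acceptor of pyrimidin-5-yl. No supporting data bear on this result. From the compounds shown here alone, whether a carboxylic acid or an amine on this aromatic ring would give a step beyond the scatter stays open. Also open, going by these compounds, is whether the same exchange behaves alike with phenyl in place of that methyl group.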